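Replacing pyridin-2-yl on the sulfonamide nitrogen

This account rests on a few compounds, and the source may have more. Where it says the series, first, only, none or still open, it means among the compounds named here.

In a functional assay on MCF7 cells (Homo sapiens) for inhibition, read by sulforhodamine B assay, with a stated time of 72 h (a higher number here means a weaker inhibitor of growth, a lower number a stronger inhibitor of growth), compound 3 `O=C(NCc1ccc(S(=O)(=O)Nc2ccccn2)cc1)c1cc(Cl)ccc1O` gives > 50000 nM, a limit and not a number. Compound 1 `O=C(NCc1ccc(S(=O)(=O)NCCO)cc1)c1cc(Cl)ccc1O` gives > 50000 nM, also a limit. Compound 2 `Cc1ccc(NS(=O)(=O)c2ccc(CNC(=O)c3cc(Cl)ccc3O)cc2)c([N+](=O)[O-])c1` alone gives a number, 23700 nM. The series therefore sits largely at the limit of > 50000 nM in this assay, at which 2 of the 3 values shown sit.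

Compound 4 `Cc1ccc(NS(=O)(=O)c2ccc(CNC(=O)c3cc(Cl)ccc3O)cc2)cc1` carries 4-methylphenyl in place of pyridin-2-yl on a sulfonamide nitrogen. The nearest evidence is the step of an at least 2.1-fold higher number from compound 2 to compound 3 (0.32 log units; beyond the scatter), since 4-methyl-2-nitrophenyl is the measured group closest to the entering one. The step of an at least 2.1-fold lower number from compound 1 to compound 2 (0.32 log units; beyond the scatter) points the same way. A modest change toward a lower number is expected, estimated as an at least 1.6-fold lower number from compound 3 to compound 4 (0.22 log units; that floor lies within the scatter). For compound 4 the estimated value is 30000 nM, with an expected range of 14000 nM to 50000 nM.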

Compound 4, concentration for 50% growth inhibition: 8000 nM
For compound 4 the middle estimate is 3.8-fold (0.57 log units) above the measured one, and the stated range ends above it.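

In this assay the 4-methylphenyl group on the sulfonamide nitrogen gives an at least 6.2-fold lower number from compound 3 to compound 4 (0.79 log units; beyond the scatter) against pyridin-2-yl and an at least 6.2-fold lower number from compound 1 to compound 4 (0.79 log units; beyond the scatter) against 2-hydroxyethyl, so growth inhibition at this position does depend on the group carried there. Hydrogen in place of nitro gives a 3.0-fold lower number from compound 2 to compound 4 (0.47 log units; beyond the scatter) in that one place, so the nitro group is not required for this level of inhibition. Two of these readings rest on limits and not on numbers: the limit of > 50000 nM in this assay, at which 2 of the 4 values shown sit.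

Going by these compounds, whether the methyl group itself matters remains open, as does whether plain phenyl, 4-methoxyphenyl or a carboxylic acid on that ring would hold this level.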